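Notes on the aryl ether change toward compound 4

This account rests on a few compounds, and the source may have more. Where it says the series, first, only, none or still open, it means among the compounds named here.

Values in an ADME assay on PBMC cells (Homo sapiens) for cytotoxicity; on this read-out higher numbers stand for lower toxicity in this test and lower numbers for higher toxicity in this test:
compound 1 `CC(CCNC(=O)c1c(Cl)cncc1Cl)N1CCC(C(Oc2ncccc2Cl)c2ccc(C(F)(F)F)cc2)CC1`: 16700 nM
compound 2 `Cc1cccc(OC(c2ccc(Br)cc2)C2CCN(C(C)CCNC(=O)c3c(Cl)cncc3Cl)CC2)n1`: 6500 nM
compound 3 `CCO/N=C(/c1ccc(Br)cc1)C1CCN(C(C)CCN(C)C(=O)c2c(C)cc[n+]([O-])c2C)CC1`: > 182000 nM, a limit of the assay

Of the two numbers in hand, compound 1 holds the higher one; compound 2 sits beyond the scatter below it. Compound 3 gives only a limit, (the limit of > 182000 nM in this assay, at which 1 of the 3 values shown sits), and no number. Compound 4 `COC(=O)c1cccc(OC(c2ccc(C(F)(F)F)cc2)C2CCN(C(C)CCNC(=O)c3c(Cl)cncc3Cl)CC2)c1` is not yet measured and differs from compound 1 in one place: 3-(methoxycarbonyl)phenyl in place of 3-chloropyridin-2-yl on an oxygen on a saturated carbon. Among the measured compounds shown here, no measured pair covers this kind of change, so in this assay a step within the scatter, in no clear direction, is expected. Compound 4 is accordingly estimated at 15000 nM, with a range from 5000 nM to 45000 nM. The implied step, a 1.1-fold lower number from compound 1 to compound 4 (0.05 log units; within the scatter), is expected to stay within the scatter.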

Compound 4, half-maximal cytotoxic concentration: 15200 nM
Compound 4: middle estimate off by 1.0-fold (0.01 log units), on the low side; measured number inside the range.
By their numbers in this assay, from the lowest: compound 2; then compounds 4 and 1 (each within the scatter of the next). At a limit, above all of these: compound 3.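

In this assay, 3-(methoxycarbonyl)phenyl in place of 3-chloropyridin-2-yl on an oxygen on a saturated carbon gives a 1.1-fold lower number from compound 1 to compound 4 (0.04 log units; within the scatter). This first single-place pair shows that, on the core of compound 1, a six-membered aromatic ring of carbon only can replace the ring with one hetero atom without a step beyond the scatter. Nothing measured here bears on the reason for this result.

From the compounds shown here alone, how a carboxylic acid in place of the methoxycarbonyl group would read in this assay stays open. Going by these compounds, an amine in that place is equally open.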